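The source may hold more compounds than are shown below. What is called first, only, known or untested is meant among the compounds shown, and "the series" means these compounds.

Measured so far in a functional assay on A549 cells (Homo sapiens) for antiproliferative activity, read by MTT assay, with a stated time of 48 h; a lower number here means a stronger inhibitor, a higher number a weaker inhibitor:
compound 1 `Clc1ccc(-c2nnc(-c3cn4ccccc4n3)o2)cc1`: 32400 nM
compound 2 `COc1cc(-c2nnc(-c3cn4ccccc4n3)o2)cc(OC)c1OC`: 2800 nM

Compound 1 holds the higher of the two numbers, which makes it the weaker inhibitor of the pair, and compound 2 lies below it by more than the scatter. Within the data shown here, these two compounds differ in more than one place, so they give no single-change step for sizing the next comparison.

Compound 3 `Brc1ccc(-c2nnc(-c3cn4ccccc4n3)o2)cc1` has not been measured. It differs from compound 1 by one exchange: bromo in place of chloro on an aromatic carbon. This is bromo in place of chloro on an aromatic carbon, or 4-chlorophenyl to 4-bromophenyl. Among the measured compounds shown here, no measured pair shows this exchange, so no direction can be assigned, and no step beyond the scatter is expected in this assay. The expected change is a 1.2-fold lower number from compound 1 to compound 3 (0.06 log units; within the scatter). The estimate for compound 3 is 28000 nM, with an expected range of 12000 nM to 60000 nM.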

Compound 3, half-maximal inhibitory concentration: > 50000 nM
Compound 3: no number, only a limit (the forecaster's own chance of this, stated with the estimate: 10%); middle value at least 1.7-fold (0.25 log units) from the limit.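

In this assay, the series now has a single-change step at this position on the aromatic ring, para to a large group, with bromo in place of chloro: an at least 1.5-fold higher number from compound 1 to compound 3 (0.18 log units; that floor lies within the scatter). Going by these compounds, compound 3 gives > 50000 nM as a limit of the assay and not a number, so only a floor for this step can be read, and its true size stays unknown. The exchange therefore shows no strengthening of inhibition, though the reading stops at the assay limit: the limit of > 50000 nM in this assay, at which 1 of the 3 values shown sits.

On these data alone, whether the step truly lies beyond the scatter remains open. Also open, as far as these compounds go, is how this position responds to groups other than the two halogens, such as an amine, a nitrile or a carboxylic acid.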